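Amide chain length and HepG2 cytotoxicity in the threonine series

The compounds below may be only part of what the source reports. "The series", "measured", "known", "first", "only" and "open" are said of these compounds alone.

Compound 1 `CCCCCCCCNC(=O)[C@@H](NC(=O)c1nccc2ccccc12)[C@@H](C)O` carries an octyl amide on its core. Among the measured compounds shown here, in a functional assay on HepG2 cells (Homo sapiens) for cytotoxicity, read by MTT assay, with a stated time of 48 h (on this read-out higher numbers stand for weaker inhibition and lower numbers for stronger inhibition), compound 1 gives 88200 nM, the only number in the set. Compound 2 `C/C=C/C=C/C(=O)N[C@H](C(=O)NCCCCCCCCCCCC)[C@@H](C)O` is reported in this assay only as a limit of the assay, > 400000 nM; it also bears a different acyl group, so the two values show no single-point comparison. Compound 3 `CCCCCCCCCCCCCCCCCCNC(=O)[C@@H](NC(=O)c1nccc2ccccc12)[C@@H](C)O` differs from compound 1 by decyl in place of hydrogen on a saturated chain carbon, eight bonds along the chain from an amide-type nitrogen. For the measured compounds named here, with no measured step on chain length, the change is expected to stay near the scatter, a 1.1-fold higher number from compound 1 to compound 3 (0.05 log units; within the scatter). Compound 3 is therefore estimated at 100000 nM, within 30000 nM to 350000 nM.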

Compound 3, half-maximal inhibitory concentration: 96900 nM
Compound 3: middle estimate off by 1.0-fold (0.01 log units), on the high side, within the range that was stated.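

In this assay, decyl in place of hydrogen on a saturated chain carbon, eight bonds along the chain from an amide-type nitrogen, gives a 1.1-fold higher number from compound 1 to compound 3 (0.04 log units; within the scatter). Among the compounds shown here, this is the only measured step at this position, and on the shared core the read-out does not separate the octyl amide from the longer chain. Compound 2 differs in its acyl group as well and stands only as a limit of the assay: the limit of > 400000 nM in this assay, at which 1 of the 3 values shown sits.

Open, from the compounds shown here alone, is whether an amine or a carboxylic acid at the chain end would move the number at this position. Chains shorter than octyl, such as butyl, also remain open on the shared core.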